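The source may report more compounds than this note shows. Statements on the series, on what has been measured and on what is new or still open speak of the compounds shown alone.

Three compounds that share one core have been examined in a physicochemical assay for metabolic stability, read by LC-MS, in phosphate buffer, with a stated time of 3 h, at pH 7.4, tested at 50 uM; on this read-out lower numbers stand for a less stable compound and higher numbers for a more stable compound. Compound 1 `CC(=O)OCOC(=O)C1=C(S[C@@H]2CN[C@H](C(=O)Nc3cccc(C(=O)OCOC(C)=O)c3)C2)[C@H](C)[C@@H]2[C@@H]([C@@H](C)O)C(=O)N12`, compound 2 `C[C@@H](O)[C@H]1C(=O)N2C(C(=O)OCOC(=O)C(C)(C)C)=C(S[C@@H]3CN[C@H](C(=O)Nc4cccc(C(=O)O)c4)C3)[C@H](C)[C@H]12` and compound 3 `C[C@@H](O)[C@H]1C(=O)N2C(C(=O)O)=C(S[C@@H]3CN[C@H](C(=O)Nc4cccc(C(=O)OCC(F)(F)F)c4)C3)[C@H](C)[C@H]12` differ from one another only in the ester groups attached to that core. In this assay compound 1 gives > 95%, which is a limit of the assay rather than a number. Compound 2 gives > 95% in this assay, again a limit. Compound 3 gives > 95% in this assay, once more a limit. Compound 2 thus stands where every measured compound stands, since (the limit of > 95% in this assay, at which 3 of the 3 values shown sit). Within the data shown here, no two measured compounds differ in a single place, so no measured step can be drawn between them.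

Compound 4 `C[C@@H](O)[C@H]1C(=O)N2C(C(=O)OCOC(=O)C3CCCCC3)=C(S[C@@H]3CN[C@H](C(=O)Nc4cccc(C(=O)O)c4)C3)[C@H](C)[C@H]12` differs from compound 2 by cyclohexyl in place of tert-butyl on a carbonyl carbon. Because (the limit of > 95% in this assay, at which 3 of the 3 values shown sit), no step beyond the usual scatter is expected for this change. The expected step is a step that the limit leaves unreadable from compound 2 to compound 4, that is, essentially none. Compound 4 is therefore expected to give about 96% in this assay, with a likely range from 88% to 99%.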

Compound 4, percent of the compound remaining: > 95%
Compound 4 gave a limit, no number (the forecaster's own chance of this, stated with the estimate: 80%); the middle value lies beyond the limit too.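

No step can be read from compound 2 to compound 4 in this assay, as both results are limits of the assay and not numbers: the limit of > 95% in this assay, at which 4 of the 4 values shown sit.

The compounds shown leave open whether any ester group on the shared core would give a readable value in this assay.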